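Replacing an aromatic group with ethyl in compound 4

The compounds below may be only part of what the source reports. "The series", "measured", "known", "first", "only" and "open" are said of these compounds alone.

compound 1 `O=C(/C=C/c1ccc(O)c(O)c1)N1CCN(c2ccccc2F)CC1` (1.43 ug/mL)
compound 2 `COc1ccccc1N1CCN(C(=O)/C=C/c2ccc(O)c(O)c2)CC1` (0.98 ug/mL)
compound 3 `O=C(/C=C/c1ccc(O)c(O)c1)N1CCN(c2ccc([N+](=O)[O-])cc2)CC1` (1.56 ug/mL)

These three values come from a functional assay on A549 cells (Homo sapiens) for antiproliferative activity, read by MTT assay, with a stated time of 48 h (a lower number here means a stronger inhibitor, a higher number a weaker inhibitor), and they lie close together. Compound 2 stands level with the other two, since every measured step stays within the scatter (a 1.5-fold lower number from compound 1 to compound 2 (0.16 log units; within the scatter) and a 1.6-fold higher number from compound 2 to compound 3 (0.20 log units; within the scatter) and also a 1.1-fold higher number from compound 1 to compound 3 (0.04 log units; within the scatter)). The next compound, compound 4 `CCN1CCN(C(=O)/C=C/c2ccc(O)c(O)c2)CC1`, has ethyl in place of 2-methoxyphenyl on an amine nitrogen in a ring. The measured steps bear on this only indirectly. Each exchanges one substituted phenyl group for another, and none removes the aromatic ring, so the data give no direct size for this change. The expectation therefore starts from compound 2 at 0.98 ug/mL and allows for a larger change than the small 1.6-fold higher number from compound 2 to compound 3 (0.20 log units; within the scatter) seen so far. In this assay a modest upward step is expected, estimated as a 2.0-fold higher number from compound 2 to compound 4 (0.31 log units; beyond the scatter) with wide uncertainty. Compound 4 is expected at 2 ug/mL with an estimated range from 0.7 ug/mL to 6 ug/mL for now.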

Compound 4, half-maximal inhibitory concentration: 6.54 ug/mL
Compound 4: middle estimate off by 3.3-fold (0.51 log units), on the low side; measured number outside the range, above it.
By their numbers in this assay, from the lowest: compounds 2, 1 and 3 (each within the scatter of the next); then compound 4.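

Until now, every swap on this amine nitrogen in a ring exchanged one substituted phenyl group for another, and the number stayed within the scatter. Removing the aromatic ring altogether gives a clear change: ethyl produces a 6.7-fold higher number from compound 2 to compound 4 (0.82 log units; beyond the scatter) and a 4.6-fold higher number from compound 1 to compound 4 (0.66 log units; beyond the scatter) and also a 4.2-fold higher number from compound 3 to compound 4 (0.62 log units; beyond the scatter) so compound 4 is the weakest of the four, whichever phenyl group it is compared with. No evidence is available to explain this loss of activity.

The compounds shown leave open whether the aromatic ring itself matters or simply a group larger than ethyl on this nitrogen. A cyclohexyl group, which keeps a ring but is not aromatic, or a longer chain such as hexyl, would help separate these two possibilities.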